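Aryl Variation on the Shared Core: Estimating Compound 4

The source may hold more compounds than are shown below. What is called first, only, known or untested is meant among the compounds shown, and "the series" means these compounds.

Working notes on three measured analogues and one unmeasured one. Compound 1 `CCC1=C(O)c2c(oc(-c3ccc(SC)cc3)cc2=O)C(CC)(CC)C1=O` carries a 4-(methylsulfanyl)phenyl group on the shared core; in a functional assay on KBVIN cells (Homo sapiens) for antiproliferative activity, read by sulforhodamine B assay, with a stated time of 3 days (on this read-out lower numbers stand for an effect already at smaller amounts and higher numbers for an effect only at larger amounts of compound), compound 1 gives 1.38 uM, the lowest of the three numbers. Compound 2 `CCC1=C(O)c2c(oc(-c3cccc(C(F)(F)F)c3)cc2=O)C(CC)(CC)C1=O` gives 5.42 uM and compound 3 `CCC1=C(O)c2c(oc(-c3cccc(OC(F)(F)F)c3)cc2=O)C(CC)(CC)C1=O` gives 9.95 uM; each of these stands beyond the scatter from compound 1. Among the measured compounds shown here, the only one-place step among the measured compounds is a 1.8-fold higher number from compound 2 to compound 3 (0.26 log units; within the scatter), trifluoromethoxy in place of trifluoromethyl on an aromatic carbon.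

Compound 4 `CCC1=C(O)c2c(oc(-c3ccc(C)c(Cl)c3)cc2=O)C(CC)(CC)C1=O` is not yet measured in this assay. It differs from compound 1 by 3-chloro-4-methylphenyl in place of 4-(methylsulfanyl)phenyl on an aromatic carbon. For the measured compounds named here, no measured step covers a 3-chloro-4-methylphenyl group, nor the loss of the methylsulfanyl acceptor, so the bearing of the one available step is indirect: it shows that a swap between two substituents on the aryl ring can stay within the scatter, while the aryl variants of compound 2 and compound 3 both sit well above compound 1. A modest rise in the number is therefore expected, a 2.2-fold higher number from compound 1 to compound 4 (0.34 log units; beyond the scatter), with the direction uncertain. Compound 4 is estimated at 3 uM, with a range from 1 uM to 9 uM.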

Compound 4, concentration for half-maximal effect: 2.15 uM
The estimate for compound 4 lay 1.4-fold (0.14 log units) above the measured number; low and high end bracket the measured number.
By their numbers in this assay, from the lowest: compounds 1 and 4 (each within the scatter of the next); then compounds 2 and 3 (each within the scatter of the next).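

In this assay the change of 3-chloro-4-methylphenyl in place of 4-(methylsulfanyl)phenyl gives a 1.6-fold higher number from compound 1 to compound 4 (0.19 log units; within the scatter). The earlier compounds shown here left compound 1 alone at the low end of the series; this result shows that the sulfur and the hydrogen-bond acceptor counted on 4-(methylsulfanyl)phenyl are not needed at this aromatic carbon, next to the ring oxygen, for a number in that range, and by their printed values compounds 1 and 4 both stay below compounds 2 and 3. Nothing measured on these groups accounts for the step, so the series offers no explanation of it.

The step exchanges the whole aryl group at once, so the separate contributions of the chlorine and the methyl of 3-chloro-4-methylphenyl cannot be told apart from the compounds shown. It also remains open whether this position keeps such numbers with an aryl group bearing an amine, a carboxylic acid or a longer alkyl chain, since none of these stands among the compounds shown.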